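Cytotoxicity of ester and sulfonate analogues in the series

A few compounds are considered here, and "the series" means these few. Any claim that something is new, unique, unknown or untested is made for them only; others in the source may bear on it.

Measured so far:
compound 1 `CCCC(=O)OC1CCC(CN2CCN(c3cc(=O)c4cc(C(F)(F)F)cc([N+](=O)[O-])c4s3)CC2)CC1` — > 64 ug/mL
compound 2 `CC(C)S(=O)(=O)OC1CCC(CN2CCN(c3cc(=O)c4cc(C(F)(F)F)cc([N+](=O)[O-])c4s3)CC2)CC1` — > 64 ug/mL
compound 3 `COc1cccc(C(=O)OC2CCC(CN3CCN(c4cc(=O)c5cc(C(F)(F)F)cc([N+](=O)[O-])c5s4)CC3)CC2)c1` — > 64 ug/mL

In an ADME assay on Vero cells (Chlorocebus sabaeus) for cytotoxicity, read by MTT assay, with a stated time of 48 h (on this read-out higher numbers stand for weaker inhibition and lower numbers for stronger inhibition), compound 1 gives > 64 ug/mL, which is a limit of the assay and not a number. Compound 2 likewise gives > 64 ug/mL in this assay, again a limit. Compound 3 gives > 64 ug/mL in this assay, also a limit. Because of the limit of > 64 ug/mL in this assay, at which 3 of the 3 values shown sit, no ordering among the three measured compounds can be read. The step that the two limits leave unreadable from compound 1 to compound 2 is unreadable, as are a step that the two limits leave unreadable from compound 1 to compound 3 and a step that the two limits leave unreadable from compound 2 to compound 3, since each end sits at a limit.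

Compound 2 therefore stands at the limit, level with every other measured compound as far as the numbers allow. The next compound is compound 4 `O=C(OC1CCC(CN2CCN(c3cc(=O)c4cc(C(F)(F)F)cc([N+](=O)[O-])c4s3)CC2)CC1)c1ccc(F)cc1`. Against compound 2 the change is (4-fluorophenyl)carbonyl in place of isopropylsulfonyl on an oxygen on a saturated carbon. The nearest measured step is that from compound 2 to compound 3, where a carbonyl-linked aromatic ring replaces the isopropylsulfonyl and the value stays at the limit. Among the measured compounds shown here, no measured step gives a readable size, so no shift beyond the scatter is expected in this assay; the step that the limit leaves unreadable from compound 2 to compound 4 is estimated to be flat. Compound 4 is expected to give about 80 ug/mL in this assay, within 40 ug/mL to 160 ug/mL, most probably as a limit again.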

Compound 4, half-maximal inhibitory concentration: > 64 ug/mL
Compound 4 ended at the assay's limit; the forecaster's own chance of this, stated with the estimate: 85%; the middle value does not contradict the limit.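

In this assay, among the compounds shown here, no step from compound 1, compound 2 or compound 3 to compound 4 can be read, because both ends of each step are limits: the limit of > 64 ug/mL in this assay, at which 4 of the 4 values shown sit.

The compounds shown leave open whether any replacement on the oxygen on a saturated carbon changes cytotoxicity, and at what concentration compound 1, compound 2, compound 3 or compound 4 would reach half-maximal inhibition.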